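Guanidine substitution on a thiazole acetamide series

The compounds below may be only part of what the source reports. "The series", "measured", "known", "first", "only" and "open" are said of these compounds alone.

Measured compounds:
compound 1 `CCNC(=N)Nc1ccc(CCc2csc(NC(C)=O)n2)cc1` gives 680 nM in an assay on CHO cells for inhibition of Amine oxidase [copper-containing] 3 (Homo sapiens), read by spectrophotometry, with stated times of 30 min and 1 h; on this read-out lower numbers stand for stronger inhibition and higher numbers for weaker inhibition
compound 2 `CC(=O)Nc1nc(CCc2ccc(NC(=N)NC(C)C)cc2)cs1` gives 1100 nM in this assay

Compound 2 carries the highest of the two numbers shown; its nearest neighbour, compound 1, differs by a 1.6-fold higher number from compound 1 to compound 2 (0.21 log units; within the scatter), a step that stays within the scatter. Compound 3 `CC(=O)Nc1nc(CCc2ccc(NC(=N)N(C)C)cc2)cs1` arises from compound 2 by one alteration: dimethylamino in place of isopropylamino on a carbon with a double bond to nitrogen. Among the compounds with values here, only one measured step bears on the guanidine end of the molecule, namely the step from compound 1 to compound 2, a 1.6-fold higher number from compound 1 to compound 2 (0.21 log units; within the scatter), and it was small. Since neither the isopropyl group nor the methyl it replaced moved this assay beyond the scatter, the move to dimethylamino is expected to do little either, so the estimated step of a 1.1-fold higher number from compound 2 to compound 3 (0.04 log units; within the scatter) is effectively none beyond the scatter. Compound 3 is therefore estimated at 1200 nM, expected to lie between 500 nM and 3000 nM.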

Compound 3, half-maximal inhibitory concentration: > 100000 nM
Compound 3: only a limit was reported; the forecaster's own chance of this, stated with the estimate: 5%; middle value at least 83-fold (1.92 log units) away from the limit.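

In this assay, within the data shown here, the earlier compounds, with ethylamino and isopropylamino on the carbon with a double bond to nitrogen, stood within the scatter of each other and gave no sign that this position could matter so sharply. Dimethylamino in place of isopropylamino gives an at least 90-fold higher number from compound 2 to compound 3 (1.95 log units; beyond the scatter), and dimethylamino in place of ethylamino gives an at least 140-fold higher number from compound 1 to compound 3 (2.16 log units; beyond the scatter). Dimethylamino counts 0 hydrogen-bond donors where the other two groups carry one, and the value of compound 3 is only a limit: the limit of > 100000 nM in this assay, at which 1 of the 3 values shown sits.

These three compounds cannot separate the loss of the hydrogen on that nitrogen from the presence of a second methyl on it. On these data alone, it remains open whether methylamino, or a cyclic amine such as pyrrolidine, on this carbon would stay near compound 1 and compound 2 or fall with compound 3.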